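From butylamino to diethylamino on the shared core

The source may hold more compounds than are shown below. What is called first, only, known or untested is meant among the compounds shown, and "the series" means these compounds.

In a functional assay on A549 cells (Homo sapiens) for cytotoxicity, read by MTT assay, with a stated time of 48 h (a higher number here means a weaker inhibitor, a lower number a stronger inhibitor), compound 1 (`COc1c(OCc2cnoc2C)cc(O)c2c(=O)cc(-c3ccccc3)oc12`) gives > 100000 nM as a limit of the assay and not as a number. Compound 2 (`CCCCNCCOc1c(O)cc(O)c2c(=O)cc(-c3ccccc3)oc12`) stands at "not determined" (no result reported) in this assay and so offers no single number as a starting point. Compound 3 (`COc1c(O)cc(O)c2c(=O)cc(-c3ccc(Cl)cc3)oc12`) also stands at "not determined" (no result reported) in this assay without a number. Compound 4 (`CCN(CC)CCCOc1c(O)cc(O)c2c(=O)cc(-c3ccccc3)oc12`) has not yet been measured. The change (diethylamino)methyl in place of butylamino on a saturated chain carbon, two bonds along the chain from an oxygen on an aromatic ring places (diethylamino)methyl in the stead of butylamino on a saturated chain carbon, two bonds along the chain from an oxygen on an aromatic ring. Within the data shown here, no measured step is available to size this change, and in this assay no step beyond the usual scatter is expected in either direction. Compound 4 is expected at 30000 nM in this assay with an estimated range of 8000 nM to 100000 nM around that figure.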

Compound 4, half-maximal inhibitory concentration: > 100000 nM
Compound 4: a limit, no number; the forecaster's own chance of this, stated with the estimate: 25%; middle value at least 3.3-fold (0.52 log units) away from the limit.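

No step can be read from compound 2 to compound 4: compound 4 gives only a limit of the assay, and compound 2 has no number. The compounds shown leave open whether replacing butylamino with (diethylamino)methyl changes the result in this assay at all.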